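Amide variation on a shared thiazinone-type core against monoamine oxidase B

A few compounds are considered here, and "the series" means these few. Any claim that something is new, unique, unknown or untested is made for them only; others in the source may bear on it.

Measured so far:
compound 1 `O=C(C/C=C/c1ccccc1)Nc1nc2ccccc2c(=O)s1` 361 nM
compound 2 `COc1cccc(CCC(=O)Nc2nc3ccccc3c(=O)s2)c1` 621 nM

Both compounds carry the same core and differ only in the acyl part of the amide. In an assay on mitochondria (strain Sprague-Dawley) for inhibition of Amine oxidase [flavin-containing] B (Rattus norvegicus), read by fluorescence and Amplex Red, with stated times of 30 min and 45 min (a higher number here means a weaker inhibitor, a lower number a stronger inhibitor), compound 1 gives 361 nM, and in this assay compound 2 gives 621 nM. Compound 2 thus holds the higher of the two numbers, but its gap to compound 1 lies within the scatter, so no order between the two can be read from these values.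

The next compound, compound 3 `O=C(CCc1ccc(Cl)c(Cl)c1)Nc1nc2ccccc2c(=O)s1`, keeps the saturated chain and the core of compound 2 and changes the aromatic group at its end: 3,4-dichlorophenyl in place of 3-methoxyphenyl on a saturated chain carbon, two bonds along the chain from a carbonyl carbon. For the measured compounds named here, no step between measured compounds informs this change, since compounds 1 and 2 differ in more than one place. The expectation for compound 3 is therefore anchored on compound 2 and its value of 621 nM, with a step that is expected to stay near or within the scatter; the estimated step is a 1.4-fold lower number from compound 2 to compound 3 (0.14 log units; within the scatter). In this assay compound 3 is expected to give 450 nM, within a range of 150 nM to 1400 nM.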

Compound 3, half-maximal inhibitory concentration: > 10000 nM
Compound 3 was reported as a limit; the forecaster's own chance of this, stated with the estimate: 5%; at least 22-fold (1.34 log units) between middle value and limit.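

The change from 3-methoxyphenyl to 3,4-dichlorophenyl on a saturated chain carbon, two bonds along the chain from a carbonyl carbon, gives an at least 16-fold higher number from compound 2 to compound 3 (1.20 log units; beyond the scatter) in this assay. The value of compound 3, > 10000 nM, is a limit of the assay and not a number, and the step rests on it: the limit of > 10000 nM in this assay, at which 1 of the 3 values shown sits. Compounds 1 and 2 differ in more than one place and could not isolate this position, whereas here the core and the saturated chain stay fixed, the leaving and entering groups have the same heavy-atom count and the same aromatic ring, and the read-out still moves beyond the scatter, so the substituents on this ring matter in this series.

The compounds shown leave open whether a 3-chlorophenyl or a 4-chlorophenyl group on the same chain would stay close to compound 2 or fall with compound 3, and where an unsubstituted phenyl group would stand. On these data alone, it is also open whether 3,4-dichlorophenyl gives a similar step on the chain of compound 1, so this single pair supports no general rule for the series.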